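The compounds below may be only part of what the source reports. "The series", "measured", "known", "first", "only" and "open" are said of these compounds alone.

Compound 1 `C=C(Br)C(=O)Nc1cccc(-c2cn3nc(-c4ccc(C)cc4)sc3n2)c1` gives 1200 nM in a functional assay on FM3A cells (Mus musculus) for inhibition, read by cell counting, with a stated time of 2 days; a higher number here means a weaker inhibitor, a lower number a stronger inhibitor. Compound 2 `C=C(Br)C(=O)Nc1cccc(-c2cn3nc(-c4cccs4)sc3n2)c1` gives 370 nM.

Among the compounds with values here, compound 2 holds the lower of the two numbers; the single measured step, a 3.2-fold lower number from compound 1 to compound 2 (0.51 log units; beyond the scatter), separates it from compound 1. Compound 3 `C=C(Br)C(=O)Nc1cccc(-c2cn3nc(Cc4ccc(OC)cc4)sc3n2)c1` differs from compound 2 by 4-methoxybenzyl in place of thiophen-2-yl on an aromatic carbon. Within the data shown here, that step swaps an aromatic ring for a benzyl group, which no measured pair covers; the only known step is of modest size and concerns two different aromatic rings. Compound 3 is therefore expected to land near compound 2, a 1.6-fold higher number from compound 2 to compound 3 (0.21 log units; within the scatter), with the estimate for compound 3 at 600 nM and a range of 200 nM to 1800 nM.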

Compound 3, half-maximal inhibitory concentration: 850 nM
Beside the measured number, compound 3's estimate is 1.4-fold (0.15 log units) below it, within the range that was stated.
By their numbers in this assay, from the lowest: compound 2; then compounds 3 and 1 (each within the scatter of the next).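

The aromatic carbon also accepts a benzyl group, but with a 2.3-fold higher number from compound 2 to compound 3 (0.36 log units; beyond the scatter), 4-methoxybenzyl does not match thiophen-2-yl in this assay. With a 1.4-fold lower number from compound 1 to compound 3 (0.15 log units; within the scatter), 4-methoxybenzyl and 4-methylphenyl cannot be told apart, so among these three groups only thiophen-2-yl gives a number set apart from the others. Nothing available explains these differences. From the compounds shown here alone, whether the lower number of compound 2 belongs to thiophene specifically or to five-membered aromatic rings more widely remains open. Going by these compounds, how a furan-2-yl ring, an amine or a carboxylic acid would fare at this carbon is also open.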